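Acetyl to carbamoyl on the shared core: cytotoxicity outlook

The source may report more compounds than this note shows. Statements on the series, on what has been measured and on what is new or still open speak of the compounds shown alone.

Measured so far:
Compound 1, `Cc1cc(NC(=O)Nc2cccc(Cl)c2)c2ccccc2n1` — 21000 nM
Compound 2, `CC(=O)c1ccc(NC(=O)Nc2cc(C)nc3ccccc23)cc1` — a limit of the assay, > 25000 nM

In an ADME assay on HEK293 cells (Homo sapiens) for cytotoxicity, with a stated time of 72 h (a lower number here means that less compound is needed, a higher number that more compound is needed for the effect), compound 1 gives 21000 nM. For compound 2 the read-out in this assay is a limit of the assay and not a number, > 25000 nM. For the measured compounds named here, compound 2 therefore stands at the limit of > 25000 nM in this assay, at which 1 of the 2 values shown sits, and no step between measured compounds can be drawn from these two values alone.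

Compound 3, `Cc1cc(NC(=O)Nc2ccc(C(N)=O)cc2)c2ccccc2n1`, differs from compound 2 by amino in place of methyl on a carbonyl carbon. Going by the values given here, with no measured step on hand, the only expectation is that the change from compound 2 to compound 3 moves the half-maximal effective concentration in this assay by about a step that the limit leaves unreadable from compound 2 to compound 3, which is no step beyond the usual scatter. Compound 3 is accordingly estimated at 30000 nM in this assay, with a range of 14000 nM to 65000 nM, and it may well again return only a limit.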

Compound 3, half-maximal effective concentration: > 25000 nM
Compound 3 gave a limit, no number (the forecaster's own chance of this, stated with the estimate: 70%); the middle value does not contradict the limit.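

Compound 2 and compound 3 both return a limit of the assay rather than a number in this assay, so no step can be read between them: the limit of > 25000 nM in this assay, at which 2 of the 3 values shown sit.

The compounds shown leave open whether acetyl to carbamoyl shifts the half-maximal effective concentration in this assay at all.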